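The compounds below may be only part of what the source reports. "The series", "measured", "known", "first", "only" and "open" are said of these compounds alone.

Working notes on the series. In an ADME assay on the whole organism with Oryza sativa as the target, tested at 1 uM (on this read-out lower numbers stand for a stronger effect and higher numbers for a weaker effect at the one concentration tested), compound 2 `CC(C)c1ccccc1NC(=O)N[C@@H](C)c1ccccc1` gives 96% and compound 1 `CC(C)c1ccccc1NC(=O)N[C@H](C)c1ccccc1` gives 101%; the two lie within the scatter of each other. Going by the values given here, the only measured step, a number 5 percentage points lower from compound 1 to compound 2 (within the scatter), rests on the fact that compounds 1 and 2 differ only in the configuration as drawn and concerns configuration alone. Compound 3 `C[C@H](NC(=O)Nc1ccccc1C(F)(F)F)c1ccccc1` differs from compound 2 by trifluoromethyl in place of isopropyl on an aromatic carbon. Among the compounds with values here, no measured step touches a substituent on an aromatic carbon, so none bears on this change and no direction can be anchored. Compound 3 is therefore expected to give 97% in this assay, between 84% and 106%. The expected step is a number 1 percentage points higher from compound 2 to compound 3 (within the scatter), not beyond the scatter.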

Compound 3, a percentage reported as activity, at one concentration (the size of the read-out at that concentration, not a potency): 98%
Compound 3: the middle estimate sits 1 percentage points below what was measured; the range from low to high includes it.
By their numbers in this assay, from the lowest: compounds 2, 3 and 1 (each within the scatter of the next).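

In this assay, going by these compounds alone, the first change at this aromatic carbon, ortho to a large group, gives a number 2 percentage points higher from compound 2 to compound 3 (within the scatter). Exchanging isopropyl for trifluoromethyl at this position therefore leaves the read-out within the scatter, which the configurational comparison could not show. Nothing available gives a cause for this step. On these data alone, whether an amine, a carboxylic acid or a longer chain at this aromatic carbon would give a step beyond the scatter remains open. So does the outcome of changes elsewhere on the shared core.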